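Dropping the Methoxycarbonyl: Cytotoxicity Stays Beyond Reach

This account rests on a few compounds, and the source may have more. Where it says the series, first, only, none or still open, it means among the compounds named here.

Three compounds built on a fused two-ring core bearing a butyl chain have been tested in an ADME assay on J774 cells (Mus musculus) for cytotoxicity; a lower number here means that less compound is needed, a higher number that more compound is needed for the effect. Compound 1 `CCCCc1cc2c(=O)c(C(=O)OC)c[nH]c2cc1OCCOc1ccccc1` carries a methoxycarbonyl group and a phenoxyethoxy side chain. In this assay compound 1 gives only a limit of the assay, > 20000 nM. Compound 3 `CCCCc1cc2c(=O)cc[nH]c2cc1OCCOc1ccccc1` is the same compound without the methoxycarbonyl group. In this assay compound 3 also gives only a limit, > 20000 nM. The change between the two is hydrogen in place of methoxycarbonyl on an aromatic carbon, and the step that the two limits leave unreadable from compound 1 to compound 3 cannot be sized because of the limit of > 20000 nM in this assay, at which 3 of the 3 values shown sit.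

Compound 2 `CCCCc1ccc2[nH]cc(C(=O)OC)c(=O)c2c1` lacks the phenoxyethoxy side chain; the difference between its core and the core of compound 1 is not broken down here. In this assay compound 2 again gives only a limit, > 20000 nM.

Compound 4 `CCCCc1ccc2[nH]ccc(=O)c2c1` has not yet been measured. It arises from compound 2 by hydrogen in place of methoxycarbonyl on an aromatic carbon, the same change as from compound 1 to compound 3, with the leaving group, the entering hydrogen and the place all matching word for word. The expected step that the limit leaves unreadable from compound 2 to compound 4 therefore rests on the unreadable step that the two limits leave unreadable from compound 1 to compound 3, which gives no reason to expect a readable number. Compound 4 is estimated at 40000 nM, with an expected range from 15000 nM to 150000 nM, and most likely only another limit will be reported.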

Compound 4, half-maximal effective concentration: > 20000 nM
Compound 4 gave a limit, no number (the forecaster's own chance of this, stated with the estimate: 85%); the middle value lies beyond the limit too.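

No size can be given for the change from compound 2 to compound 4, any more than for the same change from compound 1 to compound 3, because all of these compounds stop at a limit rather than a number: the limit of > 20000 nM in this assay, at which 4 of the 4 values shown sit.

The four compounds shown leave open how much of any of them is needed for the effect in this assay, and whether removing the methoxycarbonyl group makes any difference there.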